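Ethyl on the carboxy group of compound 2

The source may report more compounds than this note shows. Statements on the series, on what has been measured and on what is new or still open speak of the compounds shown alone.

In an ADME assay on a cell-free system (plasma, Rattus norvegicus, strain Sprague-Dawley) for metabolic stability, read by LC-MS, with a stated time of 120 min, tested at 1 uM (a higher number here means that more of the compound is left, a lower number that less of the compound is left), compound 1 `CC#CCn1c(N2CCC[C@@H](N)C2)nc2c1c(=O)n(Cc1ccc(Br)cc1C(=O)O)c(=O)n2C` gives 98.3% and compound 2 `CC#CCn1c(N2CCC[C@@H](N)C2)nc2c1c(=O)n(Cc1ccc(Cl)cc1C(=O)O)c(=O)n2C` gives 102%, so the two stand level, with practically all of the compound left. Going by the values given here, the only measured step, a number 3.7 percentage points higher from compound 1 to compound 2 (within the scatter), is chloro in place of bromo and leaves the carboxy group untouched. Compound 3 `CC#CCn1c(N2CCC[C@@H](N)C2)nc2c1c(=O)n(Cc1ccc(Cl)cc1C(=O)OCC)c(=O)n2C` differs from compound 2 by ethyl in place of hydrogen on an oxygen next to a carbonyl group, or carboxy to ethoxycarbonyl. Among the compounds with values here, no measured step covers this change, so its size is very uncertain. With compound 2 at 102%, there is no room upward, so any real step should point down. A clear drop is expected, estimated as a number 72 percentage points lower from compound 2 to compound 3 (beyond the scatter). For compound 3 the estimated value is 30%, with a range of 3% to 80%.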

Compound 3, percent of the compound remaining in the Rattus norvegicus assay: 70.2%
Estimate against measurement, compound 3: 40.2 percentage points below; the range from low to high includes it.
By their numbers in the Rattus norvegicus assay, from the lowest: compound 3; then compounds 1 and 2 (each within the scatter of the next).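

Going by these compounds alone, in the Rattus norvegicus assay compound 2 gives 102% and compound 3 gives 70.2%: ethyl on the carboxy group gives the first change beyond the scatter (a number 31.8 percentage points lower from compound 2 to compound 3 (beyond the scatter)), and the step that also carries chloro in place of bromo reads (a number 28.1 percentage points lower from compound 1 to compound 3 (beyond the scatter)). In a physicochemical assay for metabolic stability, read by LC-MS, in phosphate buffer, with a stated time of 120 min, at pH 7.4, tested at 1 uM (on this read-out lower numbers stand for a less stable compound and higher numbers for a more stable compound), compound 2 gives 101% and compound 3 gives 99.5%: the same ethyl change stays within the scatter (a number 1.5 percentage points lower from compound 2 to compound 3 (within the scatter)), so the drop does not appear there. Nothing shown here explains the drop. On these data alone, whether a methyl ester, a longer chain such as a butyl ester, or an amide in place of the ethyl ester would keep more or less of the compound remains open.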